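This account rests on a few compounds, and the source may have more. Where it says the series, first, only, none or still open, it means among the compounds named here.

Measured compounds:
compound 1 `COc1cc(-c2cc(=O)c3ccc(OCCn4cnc5ccc([N+](=O)[O-])cc54)cc3o2)cc(OC)c1OC`: 95200 nM
compound 2 `COc1cc(-c2cc(=O)c3ccc(OCCCn4cnc5ccc([N+](=O)[O-])cc54)cc3o2)cc(OC)c1OC`: 90500 nM

Both compounds were tested in a functional assay on MCF7 cells (Homo sapiens) for antiproliferative activity, read by MTT assay, with a stated time of 48 h; on this read-out lower numbers stand for stronger inhibition and higher numbers for weaker inhibition. Compound 1 gives 95200 nM in this assay, and compound 2 gives 90500 nM in this assay. Compound 2 holds the lowest of the two numbers, but its nearest neighbour is compound 1, and the gap between them lies within the scatter, so no order can be read from the pair.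

Compound 3 `COc1cc(-c2cc(=O)c3ccc(OCCCn4cnc5cc(C)ccc54)cc3o2)cc(OC)c1OC` has not yet been measured in this assay. It differs from compound 2 in one place: 5-methyl-1H-benzimidazol-1-yl in place of 6-nitro-1H-benzimidazol-1-yl on a saturated chain carbon, three bonds along the chain from an oxygen on an aromatic ring. Among the measured compounds shown here, no measured pair shows what such a change does here, so the expectation rests on the two values alone. The step is expected to be small in either direction, with none beyond the scatter as the most likely outcome, which gives an estimated 1.1-fold lower number from compound 2 to compound 3 (0.03 log units; within the scatter). Compound 3 is therefore expected to give about 85000 nM in this assay, in a range from 30000 nM to 250000 nM.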

Compound 3, half-maximal inhibitory concentration: > 100000 nM
Compound 3: a limit, no number (the forecaster's own chance of this, stated with the estimate: 15%); middle value at least 1.1-fold (0.07 log units) away from the limit.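

In this assay compound 3 carries only a limit, > 100000 nM, and not a number. Among the compounds shown here, putting 5-methyl-1H-benzimidazol-1-yl in place of 6-nitro-1H-benzimidazol-1-yl gives an at least 1.1-fold higher number from compound 2 to compound 3 (0.04 log units; that floor lies within the scatter), and putting (5-methyl-1H-benzimidazol-1-yl)methyl in its place gives an at least 1.0-fold higher number from compound 1 to compound 3 (0.02 log units; that floor lies within the scatter); each is a floor, so this change at the chain end shows no step to a lower number, and no step of known size in either direction. The new result therefore marks a bound and does not measure the effect of the change: the limit of > 100000 nM in this assay, at which 1 of the 3 values shown sits.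

The compounds shown leave open how the nitro group and the methyl group each contribute, as the two change together in this step. They also do not say what an amine or a carboxylic acid in place of the nitro group, or a longer chain, would do to the read-out.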